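The source may report more compounds than this note shows. Statements on the series, on what has been measured and on what is new or still open speak of the compounds shown alone.

Compound 2 `O=c1ccoc2ccc(OCc3cccc(F)c3)cc12` gives 1230 nM in an assay on microsomes for inhibition of Amine oxidase [flavin-containing] A (Homo sapiens), read by fluorescence and spectrophotometry, with a stated time of 20 min (on this read-out lower numbers stand for stronger inhibition and higher numbers for weaker inhibition), the highest of the two numbers measured, while compound 1 `O=c1ccoc2ccc(OCc3cccc(Cl)c3)cc12` gives 424 nM. Compound 3 `N#Cc1cccc(COc2ccc3occc(=O)c3c2)c1` carries cyano in place of fluoro on an aromatic carbon. Among the compounds with values here, the only measured step that bears on this change is a 2.9-fold higher number from compound 1 to compound 2 (0.46 log units; beyond the scatter), a modest shift between two halogens on the same aromatic carbon; the data hold no cyano compound, so the direction of a swap to cyano is uncertain. Compound 3 is expected to land near compound 2, with a step of a 1.5-fold lower number from compound 2 to compound 3 (0.19 log units; within the scatter), an estimate of 800 nM and a range from 250 nM to 2600 nM.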

Compound 3, half-maximal inhibitory concentration: 255 nM
Compound 3: the middle estimate sits 3.1-fold (0.50 log units) above what was measured; the range from low to high includes it.
By their numbers in this assay, from the lowest: compounds 3 and 1 (each within the scatter of the next); then compound 2.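

Cyano in place of fluoro gives a 4.8-fold lower number from compound 2 to compound 3 (0.68 log units; beyond the scatter) in this assay and so shows that this position, on an aromatic carbon meta to a large group, can carry a group other than a halogen without a loss. Cyano in place of chloro gives a 1.7-fold lower number from compound 1 to compound 3 (0.22 log units; within the scatter) so these two groups cannot be told apart here, and compound 2 remains the weakest of the three. On these data alone, whether an amine or a carboxylic acid at this position would keep the number in that range stays open. Nothing in the data explains these differences.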